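This account rests on a few compounds, and the source may have more. Where it says the series, first, only, none or still open, it means among the compounds named here.

In a functional assay on HeLa cells (Homo sapiens) for antiproliferative activity, with a stated time of 48 h (on this read-out higher numbers stand for weaker inhibition and lower numbers for stronger inhibition), compound 1 (`C=C(Br)C(=O)Nc1ccc(/C=C/C(=O)c2ccccc2)cc1`) gives 3900 nM, while compound 2 (`C=C(Br)C(=O)Nc1ccc(/C=C/C(=O)c2ccc(Cl)cc2)cc1`) gives 1600 nM, the lower of the two numbers. Compound 3 (`C=C(Br)C(=O)Nc1ccc(/C=C/C(=O)c2cccc(OC)c2)cc1`) differs from compound 2 in one place: 3-methoxyphenyl in place of 4-chlorophenyl on a carbonyl carbon, which is 3-methoxyphenyl in place of 4-chlorophenyl on a carbonyl carbon. Among the compounds with values here, only one measured step bears on this: a 2.4-fold lower number from compound 1 to compound 2 (0.39 log units; beyond the scatter), a modest change that came with chloro in place of hydrogen on an aromatic carbon. Within the data shown here, compound 3 has no chloro, and no measured compound carries methoxy, so a similarly modest rise is expected in this assay. The expected change is a 1.9-fold higher number from compound 2 to compound 3 (0.27 log units; within the scatter). For compound 3 the estimated value is 3000 nM, with an expected range from 1100 nM to 8000 nM.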

Compound 3, half-maximal inhibitory concentration: 700 nM
Estimate against measurement, compound 3: 4.3-fold (0.63 log units) above; measured number below the stated range.
By their numbers in this assay, from the lowest: compound 3; then compound 2; then compound 1.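

In this assay, swapping the group on the carbonyl carbon goes further than the chloro change did: 3-methoxyphenyl in place of 4-chlorophenyl gives a 2.3-fold lower number from compound 2 to compound 3 (0.36 log units; beyond the scatter), and methoxy in place of hydrogen gives a 5.6-fold lower number from compound 1 to compound 3 (0.75 log units; beyond the scatter). So chloro is not the only ring substituent that lowers the number at this ring, and methoxy lowers it further. No measurement shown explains this difference. The compounds shown leave open whether the gain follows the methoxy group itself or its place on the ring, which a 4-methoxyphenyl group would test. Going by these compounds, how an amine would behave on this ring also remains open.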